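Shortening the Side Chain: From Compound 1 to Compound 3

This account rests on a few compounds, and the source may have more. Where it says the series, first, only, none or still open, it means among the compounds named here.

Measured compounds:
compound 1 `CC(C)(C)C[C@@H](O)C(=O)N1NCC[C@H]1C(=O)NCc1cc(Cl)ccc1-n1cnnn1`: 15 10^-6 cm/s
compound 2 `O=C(NCc1cc(Cl)ccc1-n1cnnn1)[C@@H]1CC=NN1C(=O)[C@H](O)c1ccccc1`: 7 10^-6 cm/s

In an ADME assay on Caco-2 cells (Homo sapiens) for permeability, read by LC-MS, in the apical to basolateral direction, with a stated time of 60 min, at pH 6.5 (on this read-out lower numbers stand for lower permeability and higher numbers for higher permeability), compound 1 gives 15 10^-6 cm/s, the higher of the two numbers. In this assay compound 2 gives 7 10^-6 cm/s, a lower figure that lies beyond the scatter. Compound 3 `CC(C)(C)[C@@H](O)C(=O)N1NCC[C@H]1C(=O)NCc1cc(Cl)ccc1-n1cnnn1` differs from compound 1 by tert-butyl in place of neopentyl on a saturated chain carbon bound to a carbonyl carbon and an oxygen on a saturated carbon. For the measured compounds named here, no measured pair shows a step of this kind, so the expectation rests on compound 1 alone. The step of a 1.4-fold lower number from compound 1 to compound 3 (0.13 log units; within the scatter) is expected to be small, at most a mild move downward and possibly none beyond the scatter. Compound 3 is therefore expected to give 11 10^-6 cm/s, within a range from 5 10^-6 cm/s to 25 10^-6 cm/s.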

Compound 3, apparent permeability: 7.2 10^-6 cm/s
Beside the measured number, compound 3's estimate is 1.5-fold (0.18 log units) above it, and the stated range covers the measured number.
By their numbers in this assay, from the lowest: compounds 2 and 3 (each within the scatter of the next); then compound 1.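

In this assay, tert-butyl in place of neopentyl on a saturated chain carbon bound to a carbonyl carbon and an oxygen on a saturated carbon gives a 2.1-fold lower number from compound 1 to compound 3 (0.32 log units; beyond the scatter), a modest step but one beyond the scatter. This position therefore responds to a change confined to the saturated side chain. Nothing available explains the drop.

The compounds shown leave open how a longer chain, an amine or a carboxylic acid would read at this place. Going by these compounds, whether the same change would give a similar step on another core also remains open.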